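A few compounds are considered here, and "the series" means these few. Any claim that something is new, unique, unknown or untested is made for them only; others in the source may bear on it.

Working notes on the series.

Of the compounds shown here, two have been measured in a physicochemical assay for solubility, in phosphate buffer, with a stated time of 18 h, at pH 7.4; on this read-out lower numbers stand for lower solubility and higher numbers for higher solubility. Compound 1, `COc1ccc(-c2nc(N)n(-c3ncnc4ccccc34)n2)cc1`, gives 5000 nM. Compound 2, `COc1cc2ncnc(-n3nc(-c4ccccn4)nc3N)c2cc1OCc1ccccc1`, gives 58000 nM. Within the data shown here, compound 2 therefore stands with the higher of the two numbers, and the gap to compound 1 lies beyond the usual scatter of repeated measurements; no single-point step connects these two structures, so only their two values are set side by side here.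

The next compound, compound 3, `COc1cc2ncnc(-n3nc(-c4ccccn4)nc3N)c2cc1OCCCNC(=O)OCC(F)(F)F`, has not yet been measured in this assay. Its structure departs from compound 2 in one place: 2-(((2,2,2-trifluoroethoxy)carbonyl)amino)ethyl in place of phenyl on a saturated chain carbon bound to an oxygen on an aromatic ring. Cut one bond further out, the same change reads benzyl to 3-(((2,2,2-trifluoroethoxy)carbonyl)amino)propyl.

Among the measured compounds shown here, no measured step of this kind exists, so the expectation rests on the value of compound 2 alone. A modest rise is expected, a 1.9-fold higher number from compound 2 to compound 3 (0.28 log units; within the scatter), beyond the scatter but not large. Compound 3 is expected to give about 110000 nM, with a range from 45000 nM to 280000 nM.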

Compound 3, solubility: 100 nM
For compound 3 the middle estimate is 1100-fold (3.04 log units) above the measured one, outside the stated range (below it).
By their numbers in this assay, from the lowest: compound 3; then compound 1; then compound 2.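

In this assay, among these compounds, the place on a saturated chain carbon bound to an oxygen on an aromatic ring turns out to be highly sensitive to what is attached there: 2-(((2,2,2-trifluoroethoxy)carbonyl)amino)ethyl in place of phenyl gives a 580-fold lower number from compound 2 to compound 3 (2.76 log units; beyond the scatter) and this large step is the only reading of a single change so far. The change swaps a six-membered aromatic ring of carbon only for an open chain with a double bond outside aromatic rings and with a hydrogen-bond donor and hydrogen-bond acceptors, and neither group carries a net charge, so this one step cannot divide its size among those differences. No measurement shown here speaks to the reason for the step.

On these data alone, it remains open whether the lower number goes with the loss of the phenyl or with the trifluoroethoxycarbonyl end of the new chain. An unsubstituted propyl chain, a 3-aminopropyl group with a free amine or a chain ending in a carboxylic acid at this place would help separate the two, and the compounds shown include none of these groups.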